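The source may hold more compounds than are shown below. What is called first, only, known or untested is meant among the compounds shown, and "the series" means these compounds.

Measured compounds in a functional assay on HCT-15 cells (Homo sapiens) for cytotoxicity, read by CCK-8 assay; on this read-out lower numbers stand for stronger inhibition and higher numbers for weaker inhibition:
- compound 1, `Oc1ccc(-c2cc(-c3cccs3)cc(-c3ccccc3O)n2)cc1`, which reaches only the assay limit of > 50000 nM
- compound 2, `Oc1cccc(-c2cc(-c3cccs3)cc(-c3cccc(O)c3)n2)c1`, gives 3480 nM
- compound 3, `Oc1ccc(-c2cc(-c3cccs3)cc(-c3cccc(O)c3)n2)cc1`, gives 1770 nM

Compound 3 has the lowest number among the two measured values in this assay; the nearest is compound 2, whose value lies within the scatter of it, so no order between the two can be claimed. The value of compound 1 is a limit, as noted in the limit of > 50000 nM in this assay, at which 1 of the 3 values shown sits, and not a number.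

The step under consideration goes from compound 3 to compound 4, `Oc1ccc(-c2cc(-c3ccoc3)cc(-c3cccc(O)c3)n2)cc1`. The change is furan-3-yl in place of thiophen-2-yl on an aromatic carbon.

Of the measured steps, the step of an at least 28-fold lower number from compound 1 to compound 3 (1.45 log units; beyond the scatter) was large, and the step of a 2.0-fold lower number from compound 2 to compound 3 (0.29 log units; within the scatter) stayed within the scatter. Both concern the hydroxyphenyl groups, not the five-membered ring, so neither bears directly on the exchange of thiophen-2-yl for furan-3-yl. In the absence of a direct comparison, compound 4 is expected to stay within the scatter of compound 3, so the step of a 1.4-fold higher number from compound 3 to compound 4 (0.15 log units; within the scatter) is estimated to be small. Compound 4 is therefore estimated at 2500 nM in this assay, with a range from 800 nM to 8000 nM.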

Compound 4, half-maximal inhibitory concentration: 930 nM
For compound 4 the middle estimate is 2.7-fold (0.43 log units) above the measured one; measured number inside the range.
By their numbers in this assay, from the lowest: compounds 4, 3 and 2 (each within the scatter of the next, the first and the last beyond it). At a limit, above all of these: compound 1.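

In this assay, the exchange at the position opposite the ring nitrogen gave a 1.9-fold lower number from compound 3 to compound 4 (0.28 log units; within the scatter), so no change can be claimed when furan-3-yl takes the place of thiophen-2-yl. Among these compounds, the earlier compounds varied only the hydroxyphenyl groups, and their one large step belonged to those groups; this result is the first reading on the five-membered ring, and here one aromatic ring with 1 hetero atom replaced another without a step beyond the scatter. No information given here bears on this particular exchange of sulfur-containing ring for oxygen-containing ring.

Because furan-3-yl and thiophen-2-yl differ both in the hetero atom and in the ring carbon that carries the bond to the core, the compounds shown cannot separate these two features, which furan-2-yl or thiophen-3-yl could do. As far as these compounds go, it also remains open how this position responds to a group of another kind, such as an aminomethyl group, a carboxylic acid or a longer alkyl chain, and whether furan-3-yl behaves the same alongside the hydroxyphenyl arrangements of compound 1 and compound 2.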